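The source may hold more compounds than are shown below. What is called first, only, known or untested is meant among the compounds shown, and "the series" means these compounds.

Three compounds share one core and differ only in the group carried on the amide carbonyl. Within the data shown here, in an ADME assay on L6 cells (Rattus norvegicus) for cytotoxicity, read by resazurin assay, with a stated time of 70 h (a higher number here means a weaker inhibitor, a lower number a stronger inhibitor), compound 3 `COc1cc(NC(C)CCCNC(=O)/C=C/c2ccc(Cl)cc2)c2ncccc2c1` gives 16800 nM, the only plain number among the three. For compound 1 `COc1cc(NC(C)CCCNC(=O)/C(C)=C/c2ccccc2)c2ncccc2c1` this assay reports only a limit, > 250000 nM. For compound 2 `COc1ccc(/C=C/C(=O)NCCCC(C)Nc2cc(OC)cc3cccnc23)cc1` it also reports only a limit, > 240000 nM. Because of the limit of > 240000 nM in this assay, at which 1 of the 3 values shown sits, and the limit of > 250000 nM in this assay, at which 1 of the 3 values shown sits, the step that the two limits leave unreadable from compound 1 to compound 2 cannot be read, whereas the steps of an at least 14-fold lower number from compound 1 to compound 3 (1.17 log units; beyond the scatter) and an at least 14-fold lower number from compound 2 to compound 3 (1.15 log units; beyond the scatter) show compound 3 as the strongest inhibitor of the three in this assay.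

Compound 4 `COc1cc(NC(C)CCCNC(=O)/C=C/c2cccc(C(F)(F)F)c2)c2ncccc2c1` has not yet been measured. It differs from compound 3 in one place: 3-(trifluoromethyl)phenyl in place of 4-chlorophenyl on a double-bonded chain carbon bound to a double-bonded chain carbon. Among the measured compounds shown here, only one measured step changed just a substituent on that ring, the swap of chloro for methoxy from compound 2 to compound 3, and it was large; no measured step involves a trifluoromethyl group, so the direction of the new change is unclear. A step near the scatter is expected, so for compound 4 the number in this assay is estimated at 20000 nM, within 6000 nM to 70000 nM, an expected step of a 1.2-fold higher number from compound 3 to compound 4 (0.08 log units; within the scatter).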

Compound 4, half-maximal inhibitory concentration: 16200 nM
Estimate against measurement, compound 4: 1.2-fold (0.09 log units) above, and the stated range covers the measured number.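

In this assay, replacing 4-chlorophenyl with 3-(trifluoromethyl)phenyl on a double-bonded chain carbon gives a 1.0-fold lower number from compound 3 to compound 4 (0.02 log units; within the scatter), so a group of 10 heavy atoms in place of one of 7 leaves the reading at this position unchanged within the scatter. Among these compounds, the earlier compounds showed a large step for only one ring substituent, whereas an at least 14-fold lower number from compound 2 to compound 4 (1.17 log units; beyond the scatter) shows that the wide gap from the 4-methoxyphenyl compound is not unique to the 4-chlorophenyl group. That step can be given only as a minimum because compound 2 has a limit rather than a plain number: the limit of > 240000 nM in this assay, at which 1 of the 4 values shown sits.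

Compound 4 differs from compound 3 in both the ring substituent and the place it occupies on the ring, so the two changes cannot be separated; 4-(trifluoromethyl)phenyl and 3-chlorophenyl groups would be needed to tell them apart. On these data alone, it also remains open whether the reading would hold with an amine or a carboxylic acid on the ring, or whether a 3-methoxyphenyl group would behave like the 4-methoxyphenyl group of compound 2.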